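The source may hold more compounds than are shown below. What is called first, only, known or untested is meant among the compounds shown, and "the series" means these compounds.

Compound 1 `CCCCCCCCOC1CC(=O)Nc2c1c(C)nn2-c1ncnc2nc[nH]c12` and compound 2 `Cc1nn(-c2ncnc3nc[nH]c23)c2c1C(c1ccc(OC(C)C)cc1)CC(=O)N2` share one core and differ only in the group carried on a saturated ring carbon. In a functional assay on HEK293 cells for agonist activity at G-protein coupled receptor 39 (Homo sapiens), read by scintillation proximity assay and inositol phosphate accumulation, with a stated time of 75 min, in the presence of a further agent that is not named here (on this read-out higher numbers stand for an effect only at larger amounts of compound and lower numbers for an effect already at smaller amounts), compound 1 gives 8 nM, while compound 2 gives 18 nM. Going by the values given here, the single measured step is a 2.3-fold higher number from compound 1 to compound 2 (0.35 log units; beyond the scatter), so compound 2 stands with the higher of the two numbers, and the gap to compound 1 lies beyond the scatter.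

Compound 3 `Cc1nn(-c2ncnc3nc[nH]c23)c2c1C(NC(=O)Cc1cccs1)CC(=O)N2` takes this further on the same carbon: (((thiophen-2-yl)methyl)carbonyl)amino in place of 4-isopropoxyphenyl on a saturated ring carbon. Among the compounds with values here, the only step that bears on the change is the one from compound 1 to compound 2, which swapped two groups at this carbon and shifted this assay by a modest amount. The new group differs from both, bringing a hydrogen-bond donor and an amide where before there was an ether or an aryl ring, so the step is expected to be at least as large, and more likely toward a higher number, with wide uncertainty.

Compound 3 is therefore expected to give about 50 nM in this assay, within a range from 12 nM to 250 nM, which corresponds to an expected step of a 2.8-fold higher number from compound 2 to compound 3 (0.44 log units; beyond the scatter).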

Compound 3, half-maximal effective concentration: 3 nM
Compound 3: middle estimate off by 17-fold (1.22 log units), on the high side, and the stated range ends above it.
By their numbers in this assay, from the lowest: compound 3; then compound 1; then compound 2.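

Swapping 4-isopropoxyphenyl for (((thiophen-2-yl)methyl)carbonyl)amino on the saturated ring carbon in this assay gives a 6.0-fold lower number from compound 2 to compound 3 (0.78 log units; beyond the scatter) and so reverses the direction of the first step at this carbon. The same group also gives a 2.7-fold lower number from compound 1 to compound 3 (0.43 log units; beyond the scatter) when set against octyloxy, which leaves compound 3 with the lowest number of the three and shows that neither the long ether chain nor the aryl ether is needed for a low number here. This carbon therefore accepts an amide-linked group with a five-membered aromatic ring and 1 hydrogen-bond donor, and that group outperforms both earlier ones, though nothing available explains why this change lowers the number.

The compounds shown leave open which part of the entering group carries the step, since the amide hydrogen, the carbonyl and the thiophene ring all arrive together. As far as these compounds go, a version with a phenyl ring in place of the thiophene, an N-methyl amide, or a plain amine or carboxylic acid on the same carbon would begin to separate these parts, and the effect of each on this read-out remains unknown.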